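The source may report more compounds than this note shows. Statements on the series, on what has been measured and on what is new or still open speak of the compounds shown alone.

Working notes on the boronate series. Compound 1 `CCCCC/C(=C\B1OC(C)(C)C(C)(C)O1)C(O)(c1ccccc1)C1CC1` is recorded in a functional assay on HT-29 cells (Homo sapiens) for cytotoxicity, read by MTT assay, with a stated time of 72 h (a lower number here means a stronger inhibitor, a higher number a weaker inhibitor), as "not active" (no number reported), with no number reported. Compound 2 `CCC/C(=C\B1OC(C)(C)C(C)(C)O1)C(O)(c1ccccc1)C1CC1` gives 83900 nM in this assay, which is the lower of the two numbers available, and compound 3 `CCC/C(=C\B1OC(C)(C)C(C)(C)O1)C1(O)CCCc2ccccc21` gives 86800 nM; the two values sit within the scatter of each other, so no order between compound 2 and compound 3 can be read from them. Compound 4 `CCC/C(=C\B1OC(C)(C)C(C)(C)O1)C(O)c1ccccc1` has not yet been measured in this assay.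

The step from compound 2 to compound 4 is hydrogen in place of cyclopropyl on a saturated chain carbon bound to an aromatic carbon, a double-bonded chain carbon and an oxygen on a saturated carbon. Going by the values given here, no step between two measured compounds with this kind of change is available, so the expectation rests only on the level of the numbers in hand. Both measured numbers lie at the weak end of the range this assay reports, and the series gives no sign that a small change at this carbon moves the number far. For compound 4 the step from compound 2 is expected to be small, toward a somewhat higher number, and possibly not beyond the scatter, as a 1.5-fold higher number from compound 2 to compound 4 (0.19 log units; within the scatter) expresses. Compound 4 is therefore estimated at 130000 nM in this assay, expected to fall between 60000 nM and 300000 nM, with a real chance that only a limit is reported.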

Compound 4, half-maximal inhibitory concentration: > 100000 nM
Compound 4 was reported as a limit (the forecaster's own chance of this, stated with the estimate: 35%); the middle value is on the limit's open side.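

In this assay compound 4 gives > 100000 nM, which is a limit and not a number. Hydrogen in place of cyclopropyl on a saturated chain carbon bound to an aromatic carbon, a double-bonded chain carbon and an oxygen on a saturated carbon now has a step of its own, an at least 1.1-fold higher number from compound 2 to compound 4 (0.07 log units; that floor lies within the scatter), the first reading at this position, and it fixes only a floor with no upper end, so neither a small nor a large change can be told from it. The reading of this change therefore ends at the edge of what the assay reports, and it gives no sign yet that removing cyclopropyl at this carbon moves the number toward the stronger end: the limit of > 100000 nM in this assay, at which 1 of the 4 values shown sits.

Open, on these data alone, is how the number would respond at this same carbon to a methyl, an amine or a longer chain in place of cyclopropyl, since a single step with a floor gives no trend across groups. Also open, as far as these compounds go, is whether any change at this carbon, or a carboxylic acid in place of the boronate, would bring a number clearly away from the weak end of the range.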